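The source may hold more compounds than are shown below. What is called first, only, known or untested is meant among the compounds shown, and "the series" means these compounds.

In a functional assay on M21 cells (Homo sapiens) for inhibition, read by sulforhodamine B assay, with a stated time of 48 h (a lower number here means a stronger inhibitor of growth, a higher number a weaker inhibitor of growth), compound 2 `O=C(CCl)NC(=O)Nc1ccc(OC2CCCCC2)cc1` gives 5000 nM, and compound 1 `O=C(CCl)NC(=O)Nc1ccc(OC2CCCC2)cc1` gives 2900 nM. These two values lie within the scatter of each other, so compound 2 has no firm rank in this short series. Compound 3 `CC(C)(C)c1ccc(NC(=O)NC(=O)CCl)cc1` is next, with tert-butyl in place of cyclohexyloxy on an aromatic carbon. Among the measured compounds shown here, only one measured step bears on this change, a 1.7-fold higher number from compound 1 to compound 2 (0.24 log units; within the scatter). That step alters the ring on the oxygen, whereas here the oxygen and the ring both leave, so it is only a partial guide. For the measured compounds named here, no measured compound shows what replacing the whole cyclohexyloxy group does. On this limited evidence, no step beyond the scatter is expected in this assay, and no direction is favoured. The expected step is a 1.3-fold lower number from compound 2 to compound 3 (0.10 log units; within the scatter). Compound 3 is estimated at 4000 nM, with an expected range of 1600 nM to 10000 nM.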

Compound 3, concentration for 50% growth inhibition: 1100 nM
Estimate against measurement, compound 3: 3.6-fold (0.56 log units) above; measured number below the stated range.
By their numbers in this assay, from the lowest: compound 3; then compounds 1 and 2 (each within the scatter of the next).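

In this assay, among the compounds shown here, replacing the ring ether on the aromatic carbon with tert-butyl gives the first steps beyond the scatter: (a 4.5-fold lower number from compound 2 to compound 3 (0.66 log units; beyond the scatter)) and (a 2.6-fold lower number from compound 1 to compound 3 (0.42 log units; beyond the scatter)). Changing the ring size on the oxygen had not separated compound 1 from compound 2 (a 1.7-fold higher number from compound 1 to compound 2 (0.24 log units; within the scatter)), so this position responds to the replacement of the whole group, at least for these three compounds, and both modest steps run in the same direction. No measurement shown explains this difference.

The compounds shown leave open whether the oxygen, the ring or both matter, which a cyclohexyl group placed directly on the aromatic carbon or a methoxy group could separate. They also leave open how an isopropyl group or an amine would read at this position.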